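A few compounds are considered here, and "the series" means these few. Any claim that something is new, unique, unknown or untested is made for them only; others in the source may bear on it.

Measured so far:

Compound 1, `CCCc1nc2ccc(C)nc2n1Cc1ccc(-c2ccccc2-c2nn[nH]n2)cc1` — in an assay for inhibition of Type-2 angiotensin II receptor (Rattus norvegicus) (a lower number here means that less compound is needed, a higher number that more compound is needed for the effect), compound 1 gives 1 mg/kg.
Compound 2, `CCCCc1nc2c(C)cc(C)nc2n1Cc1ccc(-c2ccccc2-c2nn[nH]n2)cc1` — in this assay compound 2 gives 0.45 mg/kg.

Among the measured compounds shown here, compound 2 stands with the lowest of the two numbers; the only other value, that of compound 1, lies higher, and the gap between the two is beyond the usual scatter. Compound 3, `CCCc1nc2c(C)cc(C)nc2n1Cc1ccc(-c2ccccc2-c2nn[nH]n2)cc1`, is not yet measured. It differs from compound 2 in one place: hydrogen in place of methyl on a saturated chain carbon, three bonds along the chain from an aromatic carbon. The chain on the core is thereby shortened, which moves compound 3 toward compound 1, whose chain is of the same shorter length, while the two methyl groups on the core of compound 2 are kept. For the measured compounds named here, no measured pair shows this single change on its own. The expectation is a modest rise in the number, by a step of a 1.6-fold higher number from compound 2 to compound 3 (0.19 log units; within the scatter), though the size is uncertain. For compound 3 the estimated value in this assay is 0.7 mg/kg, within a range from 0.3 mg/kg to 1.6 mg/kg.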

Compound 3, dose for half-maximal effect: 0.087 mg/kg
Beside the measured number, compound 3's estimate is 8.0-fold (0.91 log units) above it; measured number below the stated range.
By their numbers in this assay, from the lowest: compound 3; then compound 2; then compound 1.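

Shortening the chain from butyl to propyl gives a 5.2-fold lower number from compound 2 to compound 3 (0.71 log units; beyond the scatter) in this assay, so one carbon at the end of this chain has a clear effect on the dose needed, and here the shorter chain is favoured. The methyl on the aromatic carbon of the core also matters, with its addition giving an 11-fold lower number from compound 1 to compound 3 (1.06 log units; beyond the scatter), the larger of the two single changes now readable through compound 3. Nothing available explains either step.

On these data alone, it remains open whether shortening the chain further to ethyl would lower the number again or raise it, and whether a branched chain such as isopropyl would fit the same trend. It is also unclear whether a chlorine or an ethyl group on that aromatic carbon could replace the methyl.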